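Methoxy on the phenyl of compound 2: expected effect

The source may hold more compounds than are shown below. What is called first, only, known or untested is meant among the compounds shown, and "the series" means these compounds.

Of the compounds shown here, two have numbers so far. Compound 1 `COc1ccc(-c2csc(NC(=O)COc3ccc(C(=O)c4ccccc4)cc3C)n2)cc1` gives 27100 nM in a functional assay on Ehrlich cells (Mus musculus) for cytotoxicity, read by trypan blue exclusion, with a stated time of 48 h; a lower number here means a stronger inhibitor, a higher number a weaker inhibitor. Compound 2 `Cc1ccc(C(=O)c2ccc(OCC(=O)Nc3nc(-c4ccccc4)cs3)c(C)c2)cc1` gives 28400 nM in this assay; this is the higher of the two numbers, but the gap to compound 1 lies within the scatter, so the two compounds cannot be told apart on these data. For the measured compounds named here, no step between measured compounds is available that would isolate a single change.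

Compound 3 `COc1ccc(-c2csc(NC(=O)COc3ccc(C(=O)c4ccc(C)cc4)cc3C)n2)cc1` has not been measured in this assay. It differs from compound 2 by methoxy in place of hydrogen on an aromatic carbon, sitting para to a large group; the same difference cut one bond further out reads phenyl to 4-methoxyphenyl. Compound 1 already carries this methoxy on the same phenyl and yet gives a number indistinguishable from compound 2, so the step from compound 2 to compound 3 is expected to stay within the scatter, with no direction claimed: a 1.1-fold lower number from compound 2 to compound 3 (0.02 log units; within the scatter). Compound 3 is therefore estimated at 27000 nM, with a range from 12000 nM to 60000 nM.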

Compound 3, half-maximal inhibitory concentration: 19400 nM
Beside the measured number, compound 3's estimate is 1.4-fold (0.14 log units) above it, and the stated range covers the measured number.
By their numbers in this assay, from the lowest: compounds 3, 1 and 2 (each within the scatter of the next).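

In this assay, the change from phenyl to 4-methoxyphenyl can now be read on its own, with methoxy in place of hydrogen on an aromatic carbon, para to a large group, and the step stays within the scatter (a 1.5-fold lower number from compound 2 to compound 3 (0.17 log units; within the scatter)). The second single change, which gives compound 3 a methyl group where compound 1 has a hydrogen, also stays within the scatter (a 1.4-fold lower number from compound 1 to compound 3 (0.15 log units; within the scatter)), so neither substitution separates compound 3 from its neighbour, and the series shows no measurable sensitivity to either small group in these two pairs. No supporting measurement is available that would account for these small steps.

On these data alone, it remains open whether a group of a different kind at this para place, such as an amine, a carboxylic acid or a longer alkoxy chain, would give a step beyond the scatter. Also open is whether the methoxy step would read the same on a compound without the added methyl, since the only methoxy step shown here is between compounds that both carry it.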